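Trading a Propylamino End for Aminomethyl

A few compounds are considered here, and "the series" means these few. Any claim that something is new, unique, unknown or untested is made for them only; others in the source may bear on it.

Compound 2 (`CCCNCCCCNCCCNCCC`) stands at 33000 nM in a functional assay on L1210 cells (Mus musculus) for inhibition, with a stated time of 96 h (on this read-out higher numbers stand for weaker inhibition and lower numbers for stronger inhibition), and lies within the scatter of compound 1 (`CCCNCCCNCCCCN`) with 28000 nM on that scale. The change to compound 3 (`CCCNCCCCNCCCCN`) is aminomethyl in place of propylamino on a saturated chain carbon, three bonds along the chain from an amine nitrogen. Among the measured compounds shown here, the only measured step, a 1.2-fold higher number from compound 1 to compound 2 (0.07 log units; within the scatter) for propyl in place of hydrogen on an amine nitrogen, stayed within the scatter, so no step beyond the scatter is expected in this assay here. The expected step is a 1.1-fold lower number from compound 2 to compound 3 (0.04 log units; within the scatter) in size. Compound 3 is estimated at 30000 nM with an expected range from 12000 nM to 75000 nM in this read-out.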

Compound 3, half-maximal inhibitory concentration: 600 nM
Estimate against measurement, compound 3: 50-fold (1.70 log units) above; measured number outside the range, below it.
By their numbers in this assay, from the lowest: compound 3; then compounds 1 and 2 (each within the scatter of the next).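

In this assay, aminomethyl in place of propylamino on a saturated chain carbon, three bonds along the chain from an amine nitrogen, gives a 55-fold lower number from compound 2 to compound 3 (1.74 log units; beyond the scatter). Among the compounds shown here, this position therefore responds strongly to the group it carries, which the single earlier step gave no sign of. Nothing measured here accounts for the size of this step.

Two things changed at once, the group's length and its end. A methylamino or hydroxymethyl group at this place could show how much each contributes.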